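A few compounds are considered here, and "the series" means these few. Any claim that something is new, unique, unknown or untested is made for them only; others in the source may bear on it.

Of the compounds shown here, two of the shared core have been tested in a functional assay on the whole organism for inhibition, with Mythimna separata as the target, with a stated time of 5 days; on this read-out lower numbers stand for an effect already at smaller amounts and higher numbers for an effect only at larger amounts of compound. Compound 1, whose structure is `COc1c(F)c(F)cc(-c2nnc(COc3cnn(C(C)(C)C)c(=O)c3Cl)o2)c1F`, gives in this assay only a limit of the assay, > 300 ug/mL. Compound 2, whose structure is `Cc1cc(C)cc(-c2nnc(COc3cnn(C(C)(C)C)c(=O)c3Cl)s2)c1`, likewise gives in this assay only a limit, > 300 ug/mL. So compound 2 stands at the limit and not at a number, and both values shown sit there, as the limit of > 300 ug/mL in this assay, at which 2 of the 2 values shown sit, records; neither compound shows a measurable effect within the range tested. Compound 3, whose structure is `CC(C)(C)n1ncc(OCc2nnc(-c3ccc(F)cc3)s2)c(Cl)c1=O`, has not yet been tested in this assay. It differs from compound 2 in one place: 4-fluorophenyl in place of 3,5-dimethylphenyl on an aromatic carbon. Among the measured compounds shown here, no step between measured compounds is known, since both sit at the limit, so no size or direction can be read from the data. The expected step that the limit leaves unreadable from compound 2 to compound 3 is therefore no more than none beyond the scatter, with the result most likely again a limit. For compound 3 in this assay the estimate is 400 ug/mL, in the range from 150 ug/mL to 1200 ug/mL.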

Compound 3, half-maximal effective concentration: 21.5 ug/mL
For compound 3 the middle estimate is 19-fold (1.27 log units) above the measured one; the whole stated range lies above it.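

In this assay, the place on the five-membered aromatic ring with 2 nitrogen and 1 sulfur proves sensitive to the group it carries: 4-fluorophenyl in place of 3,5-dimethylphenyl gives an at least 13-fold lower number from compound 2 to compound 3 (1.14 log units; beyond the scatter). Among the compounds shown here, the earlier compounds sat only at the limit and could not show this, so compound 3 gives the first evidence that a compound of the shared core can produce a readable effect in this assay, and that a change in this one place alone can bring it about. The true size of the step remains unknown, and only its minimum can be stated because one end of it is a limit: the limit of > 300 ug/mL in this assay, at which 2 of the 3 values shown sit.

The compounds shown leave open whether the step comes from the fluorine entering, from the two methyl groups leaving, or from both, and a plain phenyl group at this place would begin to separate these possibilities. They also leave open whether the effect survives with a different ring here, such as a pyridine, or with an amine on the phenyl ring in place of the fluorine.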